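Fluorophenyl positional isomer in the sulfonyl quinoline series

A few compounds are considered here, and "the series" means these few. Any claim that something is new, unique, unknown or untested is made for them only; others in the source may bear on it.

Measured compounds:
- compound 1, `Cc1ccc(S(=O)(=O)c2cnc3c(F)cccc3c2-c2cccc(F)c2)cc1F`: 3.92 mL/min
- compound 2, `O=S(=O)(c1ccc(F)c(F)c1)c1cnc2c(F)cccc2c1-c1cccc(F)c1`: 1.28 mL/min
- compound 3, `COc1ccc(S(=O)(=O)c2cnc3c(F)cccc3c2-c2cccc(F)c2)cc1`: 3.03 mL/min

In an ADME assay on microsomes from liver (Homo sapiens) for metabolic stability, tested at 2.5 uM (a higher number here means faster removal of the compound, a lower number slower removal), compound 1 gives the highest of the three numbers. Its nearest neighbour is compound 3, with a 1.3-fold lower number from compound 1 to compound 3 (0.11 log units; within the scatter), a gap that stays within the scatter, so the two cannot be ordered. Compound 2 lies furthest off, with a 3.1-fold lower number from compound 1 to compound 2 (0.49 log units; beyond the scatter), and the step of a 2.4-fold higher number from compound 2 to compound 3 (0.37 log units; beyond the scatter) is likewise beyond the scatter.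

Compound 4, `Cc1ccc(S(=O)(=O)c2cnc3c(F)cccc3c2-c2ccc(F)cc2)cc1F`, is the next candidate. Compared with compound 1 the change is 4-fluorophenyl in place of 3-fluorophenyl on an aromatic carbon. Among the compounds with values here, all three measured steps alter the aryl group on the sulfonyl sulfur; none touches the fluorophenyl on the shared core, so no measured step bears directly on this change. Moving a fluorine within an otherwise unchanged ring is a small alteration, and the one step that is also a fluorine-for-methyl swap on an aromatic carbon, a 3.1-fold lower number from compound 1 to compound 2 (0.49 log units; beyond the scatter), involves a different ring and a different group. The expectation for compound 4 is therefore a step of a 1.1-fold lower number from compound 1 to compound 4 (0.04 log units; within the scatter), within the scatter, with no direction predicted. Compound 4 is estimated at 3.6 mL/min in this assay, with a range of 1.8 mL/min to 7.2 mL/min.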

Compound 4, intrinsic clearance in a liver preparation (reported as CLH), per the amount of preparation that the assay uses: 2.75 mL/min
For compound 4 the middle estimate is 1.3-fold (0.12 log units) above the measured one, and the stated range covers the measured number.
By their numbers in this assay, from the lowest: compound 2; then compounds 4, 3 and 1 (each within the scatter of the next).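

Within the data shown here, compound 4 gives the first reading at this position, since every earlier step altered the aryl group on the sulfonyl sulfur and left the fluorophenyl on the shared core unchanged. In this assay, the step is a 1.4-fold lower number from compound 1 to compound 4 (0.15 log units; within the scatter), so the 3-fluorophenyl and 4-fluorophenyl groups cannot be ordered in this pair, whereas two of the three earlier steps on the sulfonyl side lie beyond the scatter. No measurement at hand explains this result or gives any property of either fluorophenyl group.

On these data alone, whether this position would read the same with anything other than a fluorophenyl group remains open, for example with an unsubstituted phenyl, a pyridine or a phenyl ring carrying an amine. Also open is whether 4-fluorophenyl in place of 3-fluorophenyl would give a step of similar size with the 3,4-difluorophenyl of compound 2 or the 4-methoxyphenyl of compound 3 on the sulfonyl sulfur, since this change is shown only with the 3-fluoro-4-methylphenyl group of compound 1.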